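The source may report more compounds than this note shows. Statements on the series, on what has been measured and on what is new or still open speak of the compounds shown alone.

Measured so far in the series:

- compound 1, `COc1ccc(-c2nc(-c3ccccc3)c(-c3ccc4c(c3)NC(=O)CO4)[nH]2)cc1`: 38.1%
- compound 2, `O=C1COc2ccc(-c3nn(-c4ccc(F)cc4)cc3-c3ccccc3)cc2N1`: 56.4%

In a functional assay on A549 cells (Homo sapiens) for cytotoxicity, read by colorimetric assay and MTT assay, with a stated time of 3 days, tested at 20 uM (a higher number here means a weaker effect of the compound at the concentration tested, a lower number a stronger effect), compound 1 gives 38.1%, the lower of the two numbers on hand. Compound 2 gives 56.4% in this assay, and the gap between the two values lies beyond the scatter, so compound 1 shows the stronger effect of the pair. Compound 2 differs from compound 1 in more than one place, so no single step can be read from these two values.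

Compound 3, `O=C1COc2ccc(-c3[nH]c(-c4ccc(F)cc4)nc3-c3ccccc3)cc2N1`, is not yet measured. It differs from compound 1 in one place: fluoro in place of methoxy on an aromatic carbon. Nothing measured in the series isolates this kind of change, so the direction of the step is open. The expected step from compound 1 to compound 3 is a number 6.9 percentage points higher from compound 1 to compound 3 (within the scatter), a small move that may well sit within the scatter. On that basis compound 3 is estimated at 45% in this assay, with a range from 25% to 65%.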

Compound 3, a percentage reported as activity, at one concentration (the size of the read-out at that concentration, not a potency): 37.5%
Beside the measured number, compound 3's estimate is 7.5 percentage points above it; measured number inside the range.
By their numbers in this assay, from the lowest: compounds 3 and 1 (each within the scatter of the next); then compound 2.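

In this assay, the exchange of 4-methoxyphenyl for 4-fluorophenyl gives a number 0.6 percentage points lower from compound 1 to compound 3 (within the scatter), the first single-place step available in the series, and the two values cannot be ordered. At this position, on an aromatic carbon para to a large group, methoxy and fluoro therefore cannot be told apart by this read-out at one concentration, although this rests on one pair and says nothing about other positions on the shared core. Nothing on hand accounts for this outcome.

Still open, going by these compounds, is whether this position accepts groups of a different kind, such as an amine, a carboxylic acid or a longer chain such as butoxy, or whether the same insensitivity would hold for them. Among the compounds shown here, also open is what sets compound 2 apart, as it differs from the other two compounds in more than one place, so no step to it can be read.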